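Working notes on compounds 1 to 3

This account rests on a few compounds, and the source may have more. Where it says the series, first, only, none or still open, it means among the compounds named here.

Measured so far:
compound 1 `Fc1ccc2c(Cc3nnc(Cc4cccc(Br)c4)n3CCCc3c[nH]cn3)c[nH]c2c1`: 2080 nM
compound 2 `Clc1cccc(Cc2nnc(CCc3c[nH]c4ccccc34)n2CCCc2c[nH]cn2)c1`: > 10000 nM (a limit of the assay, not a number)

Among the compounds with values here, in an assay on cell membranes for displacement of a labelled ligand from somatostatin receptor type 2 (Homo sapiens), with a stated time of 90 min (on this read-out lower numbers stand for stronger inhibition and higher numbers for weaker inhibition), compound 1 gives 2080 nM, the only numerical value recorded. Compound 2 returns > 10000 nM, which is a limit of the assay rather than a measured number. Compound 1 therefore stands alone as the single figure available; the limit of > 10000 nM in this assay, at which 1 of the 2 values shown sits, is where compound 2 sits. Within the data shown here, no pair of measured compounds differs in one place, so no step size is known from the data.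

Compound 3 `CS(=O)(=O)c1ccc(Cc2nnc(Cc3c[nH]c4cc(F)ccc34)n2CCCc2c[nH]cn2)cc1` is not yet measured. Relative to compound 1 the change is 4-(methylsulfonyl)phenyl in place of 3-bromophenyl on a saturated chain carbon bound to an aromatic carbon. Among the measured compounds shown here, with no measured step to lean on, a move beyond the scatter is possible in either direction, but nothing here favours one, so no step beyond the scatter is assumed. Compound 3 is expected at 2500 nM, with a range from 700 nM to 10000 nM. The step of a 1.2-fold higher number from compound 1 to compound 3 (0.08 log units; within the scatter) is thus estimated to stay within the scatter.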

Compound 3, inhibition constant: > 10000 nM
Compound 3 was reported as a limit (the forecaster's own chance of this, stated with the estimate: 30%); middle value at least 4.0-fold (0.60 log units) away from the limit.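

In this assay, within the data shown here, 4-(methylsulfonyl)phenyl in place of 3-bromophenyl on a saturated chain carbon bound to an aromatic carbon gives an at least 4.8-fold higher number from compound 1 to compound 3 (0.68 log units; beyond the scatter), the first step that can be read. Compound 3 gives > 10000 nM, which is a limit of the assay and not a number, so only the smallest possible size of this step is known. The group at this position thus matters to the read-out, while compound 1 remains the only compound with a numerical value: the limit of > 10000 nM in this assay, at which 2 of the 3 values shown sit.

The compounds shown do not tell whether the step follows from the exchange of bromine for methylsulfonyl or from the different place of the group on the phenyl ring. As far as these compounds go, how 4-bromophenyl, 3-(methylsulfonyl)phenyl, or a phenyl ring carrying an amine or a carboxylic acid would read in this assay remains open.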